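Thiophene for phenyl on the shared core: a forecast

This account rests on a few compounds, and the source may have more. Where it says the series, first, only, none or still open, it means among the compounds named here.

Measured so far:
compound 1 `c1ccc(-c2cn3ccnc3c(-c3ccc4ncn(C5CCCCC5)c4c3)n2)cc1`: 39.6%
compound 2 `c1cn2cc(-c3ccsc3)nc(-c3ccc4ncn(C5CCCCC5)c4c3)c2n1`: 4.9%
compound 3 `Brc1ccc(-c2cn3ccnc3c(-c3ccc4ncn(C5CCCCC5)c4c3)n2)cc1`: 30.7%

Of the compounds shown here, three have been tested in a functional assay on LOX IMVI cells (Homo sapiens) for inhibition, read by sulforhodamine B assay, with a stated time of 48 h, tested at 10 uM; on this read-out higher numbers stand for more inhibition at the one concentration tested (going by the name of the read-out) and lower numbers for less inhibition. Among them, compound 1 gives the highest number, 39.6%; compound 3 sits closest, with a number 8.9 percentage points lower from compound 1 to compound 3 (within the scatter), and compound 2 furthest, with a number 34.7 percentage points lower from compound 1 to compound 2 (beyond the scatter). Compound 4 `c1csc(-c2cn3ccnc3c(-c3ccc4ncn(C5CCCCC5)c4c3)n2)c1` has not yet been measured. It differs from compound 1 in one place: thiophen-2-yl in place of phenyl on an aromatic carbon. For the measured compounds named here, the step that bears on this change is the one from compound 1 to compound 2, where a thiophen-3-yl replaced the phenyl and the number fell by a number 34.7 percentage points lower from compound 1 to compound 2 (beyond the scatter), a large drop. The step from compound 2 to compound 3, a number 25.8 percentage points higher from compound 2 to compound 3 (beyond the scatter), points the same way: the compound bearing the thiophene gives the lowest number of the three. The bromo step, a number 8.9 percentage points lower from compound 1 to compound 3 (within the scatter), says little here. With thiophen-2-yl rather than thiophen-3-yl entering, compound 4 is therefore expected to fall below compound 1 by about a number 24.6 percentage points lower from compound 1 to compound 4 (beyond the scatter), though whether the drop is as steep as for compound 2 is uncertain. Compound 4 is estimated at 15%, in a range from 0% to 38%.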

Compound 4, a percentage reported as inhibition, at one concentration (the size of the read-out at that concentration, not a potency): 1.07%
Beside the measured number, compound 4's estimate is 13.9 percentage points above it, and the stated range covers the measured number.
By their numbers in this assay, from the lowest: compounds 4 and 2 (each within the scatter of the next); then compounds 3 and 1 (each within the scatter of the next).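

In this assay, the loss seen with thiophen-3-yl does not depend on how the thiophene is attached: thiophen-2-yl at this position shows a number 38.5 percentage points lower from compound 1 to compound 4 (beyond the scatter), while a number 3.8 percentage points lower from compound 2 to compound 4 (within the scatter) leaves the two thiophenes unresolved. The 4-bromophenyl group also stands clear of thiophen-2-yl, with a number 29.6 percentage points lower from compound 3 to compound 4 (beyond the scatter), so across these four compounds the two six-membered carbon rings read higher than the two thiophenes, and none of the four goes against this. No evidence accompanies the result that would account for this split.

The compounds shown leave open how a furan-2-yl, a pyridin-3-yl or a phenyl carrying an amine would read at this position. They also leave open whether any group here could take the number past compound 1 at 39.6%.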